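A few compounds are considered here, and "the series" means these few. Any claim that something is new, unique, unknown or untested is made for them only; others in the source may bear on it.

Measured so far in a functional assay on L5178Y cells (Mus musculus) for inhibition, read by MTT assay, with a stated time of 24 h; on this read-out higher numbers stand for weaker inhibition and lower numbers for stronger inhibition:
compound 1 `COc1cc(O)c2c(c1)O[C@H](c1ccc(O)cc1)C/C2=N\Nc1ccccc1`: >= 11300 nM
compound 2 `COc1ccc([C@@H]2C/C(=N\Nc3ccccc3)c3c(O)cc(OC)cc3O2)cc1`: >= 11300 nM

Neither entry is a number. For compound 1, >= 11300 nM is a limit of the assay. For compound 2, >= 11300 nM is also a limit of the assay, so this compound has only a limit and no measured value. Both measured compounds sit at the limit of >= 11300 nM in this assay, at which 2 of the 2 values shown sit.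

Compound 3 `COc1ccc([C@@H]2C/C(=N\NC(=O)OCc3ccccc3)c3c(O)cc(OC)cc3O2)cc1` differs from compound 2 by benzyloxycarbonyl in place of phenyl on an amine nitrogen. Among the compounds with values here, the only measured step is a step that the two limits leave unreadable from compound 1 to compound 2. That step is a methyl in place of hydrogen on an oxygen on an aromatic ring, a different change in a different place, and it supplies no size to carry over. Within the data shown here, no measured compound varies the group on the amine nitrogen.

No direction can therefore be expected with any confidence, and no step beyond the scatter is predicted. The estimated change is a step that the limit leaves unreadable from compound 2 to compound 3, and it is expected to be poorly defined. The most likely outcome is expected to be another reading near the same limit. For compound 3 the estimated value is 12000 nM, with an expected range of 4000 nM to 30000 nM.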

Compound 3, half-maximal inhibitory concentration: > 100000 nM
Compound 3 ended at the assay's limit; the forecaster's own chance of this, stated with the estimate: 70%; at least 8.3-fold (0.92 log units) between middle value and limit.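

In this assay compound 3 gives > 100000 nM, which is a limit of the assay. Compound 2 gives >= 11300 nM, also a limit. No step can be read between compound 2 and compound 3. The compounds shown leave open whether benzyloxycarbonyl in place of phenyl on an amine nitrogen shifts inhibition at all, and by how much.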